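Fluorine for Methyl on the Aryl Group of a Fused Core

The compounds below may be only part of what the source reports. "The series", "measured", "known", "first", "only" and "open" are said of these compounds alone.

Three measured compounds share one core and differ only in the aromatic group attached to it. Compound 1 `COc1cc(F)ccc1-c1cc2c(cn1)ncn2-c1ccc(OC(F)F)cc1` gives 93 nM in a functional assay on HL-60 cells (Homo sapiens) for activation, read by flow cytometry, with a stated time of 4 days; a lower number here means that less compound is needed, a higher number that more compound is needed for the effect. Compound 2 `CCc1ccccc1-c1cc2c(cn1)ncn2-c1ccc(OC(F)F)cc1` gives 2900 nM in this assay, and compound 3 `Cc1ccc(-c2cc3c(cn2)ncn3-c2ccc(OC(F)F)cc2)c(C)c1` gives 180 nM. Compound 3 thus holds the second highest of the three numbers: compound 1 is its nearest neighbour, with a 1.9-fold higher number from compound 1 to compound 3 (0.29 log units; within the scatter), while compound 2 is furthest, with a 16-fold lower number from compound 2 to compound 3 (1.21 log units; beyond the scatter).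

Compound 4 `Cc1cc(F)c(F)cc1-c1cc2c(cn1)ncn2-c1ccc(OC(F)F)cc1` has not yet been measured in this assay. It alters the same aromatic group: 4,5-difluoro-2-methylphenyl in place of 2,4-dimethylphenyl on an aromatic carbon. All three measured steps change this group, so all bear on the question. Both large steps involve 2-ethylphenyl, namely a 31-fold higher number from compound 1 to compound 2 (1.49 log units; beyond the scatter) and a 16-fold lower number from compound 2 to compound 3 (1.21 log units; beyond the scatter), whereas moving between 4-fluoro-2-methoxyphenyl and 2,4-dimethylphenyl gave only a 1.9-fold higher number from compound 1 to compound 3 (0.29 log units; within the scatter). Compound 4 keeps a methyl and brings in fluorine, which compound 1 also carries, so the expected step is a 1.2-fold lower number from compound 3 to compound 4 (0.08 log units; within the scatter), within the scatter. Compound 4 is therefore estimated at 150 nM, with a range from 50 nM to 500 nM.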

Compound 4, half-maximal effective concentration: 220 nM
Compound 4: middle estimate off by 1.5-fold (0.17 log units), on the low side; the range from low to high includes it.
By their numbers in this assay, from the lowest: compounds 1, 3 and 4 (each within the scatter of the next, the first and the last beyond it); then compound 2.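

Placing 4,5-difluoro-2-methylphenyl where 2,4-dimethylphenyl stood leaves the number within the scatter, a 1.2-fold higher number from compound 3 to compound 4 (0.09 log units; within the scatter), so this position tolerates these fluorines on the aryl group without a measurable change in this assay. This third aryl group also stays far from the 2-ethylphenyl compound, a 13-fold lower number from compound 2 to compound 4 (1.12 log units; beyond the scatter), which makes 2-ethylphenyl the only clear outlier among the four compounds. The first gap beyond the scatter among the other three compounds now appears, though it is modest, a 2.4-fold higher number from compound 1 to compound 4 (0.37 log units; beyond the scatter), while compound 3 lies within the scatter of both.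

From the compounds shown here alone, it remains open how this position would respond to an amine or a carboxylic acid on the aryl group, or to a chain longer than ethyl. Nothing shown here explains the differences between these numbers.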